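Notes on the shared-core series: bromo to cyano step

The compounds below may be only part of what the source reports. "The series", "measured", "known", "first", "only" and "open" are said of these compounds alone.

Compound 1 `COc1ccc(-c2cc3c(n2-c2ccc(O)c(C(=O)O)c2)CCCC3)cc1` gives 50% in a functional assay on the whole organism (strain Wistar) for inhibition, with Rattus norvegicus as the target, read by paw edema, with stated times of 30 min and 3 h, at a dose of 200 mg/kg by the oral route; on this read-out higher numbers stand for more inhibition at the one dose given (going by the name of the read-out) and lower numbers for less inhibition.
Compound 2 `COc1cccc(-c2cc3c(n2-c2ccc(O)c(C(=O)O)c2)CCCC3)c1` gives 20% in this assay.
Compound 3 `O=C(O)c1cc(-n2c(-c3ccc(Br)cc3)cc3c2CCCC3)ccc1O` gives 40% in this assay.

Compound 3 stands second highest of the three numbers as they stand. Its nearest neighbour is compound 1, with a number 10 percentage points lower from compound 1 to compound 3 (within the scatter), a step within the scatter, so the two cannot be ranked. Compound 2 lies further off, with a number 20 percentage points higher from compound 2 to compound 3 (beyond the scatter), beyond the scatter. The remaining step, a number 30 percentage points lower from compound 1 to compound 2 (beyond the scatter), moves the methoxy group and does not touch the position changed here.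

Compound 4 `N#Cc1ccc(-c2cc3c(n2-c2ccc(O)c(C(=O)O)c2)CCCC3)cc1` has not been measured in this assay. Its difference from compound 3 is cyano in place of bromo on an aromatic carbon. Within the data shown here, no measured step introduces a cyano group. Among the measured compounds shown here, the only measured exchange at this position, a number 10 percentage points lower from compound 1 to compound 3 (within the scatter), lay within the scatter, so a substituent swap there has so far shifted the read-out little. On that basis the expected step is no change at the digits printed from compound 3 to compound 4 (within the scatter), none beyond the scatter. Compound 4 is therefore estimated at 40%, with a range of 20% to 60%.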

Compound 4, a percentage reported as inhibition, in the whole organism at one dose (the size of the read-out at that dose, not a potency): 0%
For compound 4 the middle estimate is 40 percentage points above the measured one, and the stated range ends above it.
By their numbers in this assay, from the lowest: compound 4; then compound 2; then compounds 3 and 1 (each within the scatter of the next).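

In this assay the change from 4-bromophenyl to 4-cyanophenyl gives a number 40 percentage points lower from compound 3 to compound 4 (beyond the scatter), so this position does respond to the group it carries, which the exchange of methoxy for bromo, lying within the scatter, did not reveal. The cyano compound also separates from both methoxy compounds, with a number 50 percentage points lower from compound 1 to compound 4 (beyond the scatter) for cyano in place of methoxy and a number 20 percentage points lower from compound 2 to compound 4 (beyond the scatter) for 4-cyanophenyl in place of 3-methoxyphenyl, which places compound 4 lowest of the four, beyond the scatter on every step. Nothing in the available data accounts for this drop.

On these data alone, whether the drop is confined to cyano or extends to other groups at this place, such as chloro, an amine or an amide, remains open. As far as these compounds go, with a single oral dose, it also remains open whether compound 4 would show any inhibition at a higher dose.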